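The source may hold more compounds than are shown below. What is called first, only, known or untested is meant among the compounds shown, and "the series" means these compounds.

Compound 1 `COc1ccccc1S(=O)(=O)Nc1ccc2oc(-c3ccccc3)nc2c1` is the starting point of this account. In an assay on isolated protein for inhibition of malate dehydrogenase, mitochondrial (Sus scrofa), with stated times of 45 min and 30 min (on this read-out higher numbers stand for weaker inhibition and lower numbers for stronger inhibition), compound 1 gives only a limit, > 63000 nM, and not a number. Compound 2 `COc1ccc(S(=O)(=O)Nc2ccc3oc(-c4ccccc4)nc3c2)cc1` carries the same core with the methoxy group moved to the other position on the ring attached to the sulfonyl sulfur. In this assay compound 2 likewise returns only a limit, > 63000 nM, and no number. The step that the two limits leave unreadable from compound 1 to compound 2 therefore cannot be read, since both ends sit at the limit of > 63000 nM in this assay, at which 2 of the 2 values shown sit. Compound 2 thus stands at the limit of this assay, with no measured value to place it against the second compound beyond that limit.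

Compound 3 `O=S(=O)(Nc1ccc2oc(-c3ccccc3)nc2c1)c1ccccc1O` differs from compound 2 by 2-hydroxyphenyl in place of 4-methoxyphenyl on a sulfonyl sulfur. Among the measured compounds shown here, the only measured step in the set, the one from compound 1 to compound 2, concerns the same ring on the sulfonyl sulfur, and its size is not readable, so no measured step gives a direction for this change. Compound 3 is therefore expected to sit near the same limit, with an estimated value of 100000 nM and a range from 20000 nM to 500000 nM. The estimated step that the limit leaves unreadable from compound 2 to compound 3 is expected to be none beyond the scatter.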

Compound 3, half-maximal inhibitory concentration: > 63000 nM
Compound 3 gave a limit, no number; the forecaster's own chance of this, stated with the estimate: 80%; the middle value lies beyond the limit too.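

In this assay compound 3 gives > 63000 nM, a limit and not a number. Among the compounds shown here, no step from compound 1 or compound 2 to compound 3 can be read, since all three compounds sit at the same limit: the limit of > 63000 nM in this assay, at which 3 of the 3 values shown sit. The compounds shown leave open how strongly any of them inhibits the enzyme, and whether any group on the sulfonyl sulfur would give a measurable value in this assay.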